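From pyrrolidin-1-yl to piperidin-1-yl on the carbonyl

The source may report more compounds than this note shows. Statements on the series, on what has been measured and on what is new or still open speak of the compounds shown alone.

Of the compounds shown here, three sharing one core have been read in a physicochemical assay for solubility, read by HPLC, in phosphate buffer, measured as kinetic solubility, at pH 7.4; on this read-out higher numbers stand for higher solubility and lower numbers for lower solubility. Compound 1 (`CCCC(=O)c1cc(-c2ccc(S(N)(=O)=O)cc2)n(-c2ccc(Cl)cc2)n1`), with propyl on the carbonyl carbon, gives 25800 nM. Compound 2 (`NS(=O)(=O)c1ccc(-c2cc(C(=O)N3CC4CC4C3)nn2-c2ccc(Cl)cc2)cc1`) gives 36600 nM. Compound 3 (`NS(=O)(=O)c1ccc(-c2cc(C(=O)N3CCCC3)nn2-c2ccc(Cl)cc2)cc1`), with pyrrolidin-1-yl in that place, gives 57900 nM.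

Compound 3 stands apart from compound 1 only modestly, with a 2.2-fold higher number from compound 1 to compound 3 (0.35 log units; beyond the scatter). It cannot be separated from compound 2, as the data show a 1.6-fold higher number from compound 2 to compound 3 (0.20 log units; within the scatter). The remaining pair shows a 1.4-fold higher number from compound 1 to compound 2 (0.15 log units; within the scatter).

Compound 4 (`NS(=O)(=O)c1ccc(-c2cc(C(=O)N3CCCCC3)nn2-c2ccc(Cl)cc2)cc1`) is the next to be read. The change is piperidin-1-yl in place of pyrrolidin-1-yl on a carbonyl carbon; in words, piperidin-1-yl in place of pyrrolidin-1-yl on a carbonyl carbon.

Within the data shown here, no measured step makes this exact exchange. The closest evidence is compound 2, whose group has the same heavy-atom count as piperidin-1-yl and which differs from the pyrrolidin-1-yl compound by a 1.6-fold higher number from compound 2 to compound 3 (0.20 log units; within the scatter). The wider step to propyl, a 2.2-fold higher number from compound 1 to compound 3 (0.35 log units; beyond the scatter), is still modest. Only a small move in this assay is therefore expected, towards a lower number and not beyond the scatter. The expected step is a 1.4-fold lower number from compound 3 to compound 4 (0.14 log units; within the scatter). Compound 4 is estimated at 42000 nM, with an expected range of 20000 nM to 75000 nM.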

Compound 4, solubility: 65900 nM
Compound 4: the middle estimate sits 1.6-fold (0.20 log units) below what was measured; low and high end bracket the measured number.
By their numbers in this assay, from the lowest: compounds 1, 2, 3 and 4 (each within the scatter of the next, the first and the last beyond it).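

In this assay, piperidin-1-yl in place of pyrrolidin-1-yl on the carbonyl carbon gives a 1.1-fold higher number from compound 3 to compound 4 (0.06 log units; within the scatter), so the exchange of the five-membered ring for the six-membered ring cannot be resolved at this position; the comparison with the group of compound 2, a 1.8-fold higher number from compound 2 to compound 4 (0.26 log units; within the scatter), cannot be resolved either. Against propyl, the new ring gives a 2.6-fold higher number from compound 1 to compound 4 (0.41 log units; beyond the scatter), which is a second modest step beyond the scatter alongside a 2.2-fold higher number from compound 1 to compound 3 (0.35 log units; beyond the scatter), while the group of compound 2 goes against this pattern with a 1.4-fold higher number from compound 1 to compound 2 (0.15 log units; within the scatter). No measurement shown here accounts for these steps or for the difference between the three ring groups.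

Still open, from the compounds shown here alone, is whether a morpholine or piperazine ring, or an open-chain amine such as dimethylamino, on the carbonyl carbon would give a step larger than those seen so far in this assay. The rest of the shared core is identical in all four compounds, so these notes cannot say whether the steps on the carbonyl carbon would hold with a different group elsewhere on the core.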